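Replacing the Chlorophenyl on the Ring Amine with Ethoxyphenyl

A few compounds are considered here, and "the series" means these few. Any claim that something is new, unique, unknown or untested is made for them only; others in the source may bear on it.

Compound 1 `CC(C)Cc1ccc(C(C)c2nn(CN3CCN(c4ccc([N+](=O)[O-])cc4)CC3)c(=S)o2)cc1`: 75.1%
Compound 2 `CSc1ccc(Cc2nn(CN3CCN(c4ccc(Cl)cc4)CC3)c(=S)o2)cc1`: 71.1%
Compound 3 `CSc1ccc(Cc2nn(CN3CCN(c4cccc(Cl)c4)CC3)c(=S)o2)cc1`: 74.7%

In a functional assay on the whole organism (strain Wister albino) for inhibition, with Rattus norvegicus as the target, read by paw edema, with stated times of 30 min and 3 h, at a dose of 10 mg/kg by the oral route (on this read-out higher numbers stand for more inhibition at the one dose given (going by the name of the read-out) and lower numbers for less inhibition), compound 3 gives 74.7%, the second highest of the three numbers; compound 1 gives 75.1% and compound 2 gives 71.1%, both within the scatter of compound 3. Going by the values given here, the only step at the same place is a number 3.6 percentage points higher from compound 2 to compound 3 (within the scatter), which lies within the scatter. Compound 4 `CCOc1ccccc1N1CCN(Cn2nc(Cc3ccc(SC)cc3)oc2=S)CC1` differs from compound 3 by 2-ethoxyphenyl in place of 3-chlorophenyl on an amine nitrogen in a ring. Among the compounds with values here, no measured step brings in an ethoxy group, so the single step at this position is the only guide, and it suggests no step beyond the scatter. Compound 4 is therefore expected to give about 72%, between 60% and 82%, a step of a number 2.7 percentage points lower from compound 3 to compound 4 (within the scatter).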

Compound 4, a percentage reported as inhibition, in the whole organism at one dose (the size of the read-out at that dose, not a potency): 42.5%
Estimate against measurement, compound 4: 29.5 percentage points above; the whole stated range lies above it.
By their numbers in this assay, from the lowest: compound 4; then compounds 2, 3 and 1 (each within the scatter of the next).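

At this position on the ring amine, the earlier chlorophenyl pair suggested little sensitivity, but in this assay the 2-ethoxyphenyl group gives a number 32.2 percentage points lower from compound 3 to compound 4 (beyond the scatter). Against the other chlorophenyl it gives a number 28.6 percentage points lower from compound 2 to compound 4 (beyond the scatter), so the position does respond to the group it carries, at least for this exchange. Nothing measured here explains the loss. As far as these compounds go, it remains open whether the loss follows the ethoxy group itself or its ring position. A 4-ethoxyphenyl, a 2-chlorophenyl or a 2-methoxyphenyl group on the same nitrogen would help separate these possibilities.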